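This account rests on a few compounds, and the source may have more. Where it says the series, first, only, none or still open, it means among the compounds named here.

Series notes, pyridazinone carbothioamides in a functional assay on the whole organism (stomach) with Rattus norvegicus as the target; a lower number here means that less compound is needed, a higher number that more compound is needed for the effect.

Compound 3 `Cc1ccc(=O)n(CCCC(=N)S)n1` gives > 100 mg/kg in this assay, a limit of the assay and not a number. Compound 1 `Cc1ccc(=O)n(CCCCCC(=N)S)n1` gives > 100 mg/kg, again a limit and not a number. Within the data shown here, compound 2 `N=C(S)CCn1nc(-c2ccccc2)ccc1=O` is the only member with a number: in this assay it gives 87.3 mg/kg. How the core of compound 2 differs from the core of compound 3 is not broken down here.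

The change from compound 3 to compound 1 is a group of 5 heavy atoms (3 carbon, 1 nitrogen, 1 sulfur; no ring) in place of a group of 3 heavy atoms (1 carbon, 1 nitrogen, 1 sulfur; no ring), on a saturated chain carbon, three bonds along the chain from an aromatic nitrogen; its step that the two limits leave unreadable from compound 3 to compound 1 is unreadable, since both ends sit at the limit of > 100 mg/kg in this assay, at which 2 of the 3 values shown sit.

Compound 4 `N=C(S)CCCCn1nc(-c2ccccc2)ccc1=O` carries the same kind of change relative to compound 2, (a group of 5 heavy atoms (3 carbon, 1 nitrogen, 1 sulfur; no ring) in place of a group of 3 heavy atoms (1 carbon, 1 nitrogen, 1 sulfur; no ring), on a saturated chain carbon, two bonds along the chain from an aromatic nitrogen), but the place differs: two bonds along the chain from an aromatic nitrogen rather than three. No readable measured step exists for this change, so the step from compound 2 to compound 4 is expected to be small, a 1.0-fold higher number from compound 2 to compound 4 (0.01 log units; within the scatter), within the usual scatter, resting only on the value of compound 2, 87.3 mg/kg. Compound 4 is therefore estimated at 90 mg/kg, with a range from 40 mg/kg to 200 mg/kg, and a fair chance that only a limit is reported.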

Compound 4, dose for half-maximal effect: > 100 mg/kg
Compound 4: no number, only a limit (the forecaster's own chance of this, stated with the estimate: 35%); at least 1.1-fold (0.04 log units) between middle value and limit.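

In this assay compound 4 gives > 100 mg/kg, a limit of the assay and not a number. On the core of compound 2, the group of 5 heavy atoms in place of the group of 3 heavy atoms is therefore an at least 1.1-fold higher number from compound 2 to compound 4 (0.05 log units; that floor lies within the scatter), a floor that leaves the true size of the step unknown and does not show that the change matters on this core. Whether the change carries from one core to the other cannot be judged, because the step on the core of compound 3 cannot be read, with both of its ends at a limit: the limit of > 100 mg/kg in this assay, at which 3 of the 4 values shown sit.

Open, going by these compounds, is what a longer chain, or an amine or a carboxylic acid in place of the carbothioamide, would give on the core of compound 2. Equally open, on these data alone, is how far the three compounds at the limit lie past it.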